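Working notes: the amide series, change at the ring nitrogen

The source may hold more compounds than are shown below. What is called first, only, known or untested is meant among the compounds shown, and "the series" means these compounds.

Measured compounds:
compound 1 `CCn1c(CN2CCN(C(=O)C3CC3)CC2)nc2ccccc21`: 20.8%
compound 2 `Cc1cccc(Cn2c(CN3CCN(C(=O)c4cccnc4)CC3)nc3ccccc32)c1`: 24.5%
compound 3 `Cc1cccc(Cn2c(CN3CCN(C(=O)CC(C)C)CC3)nc3ccccc32)c1`: 71.4%

In an assay on isolated protein for inhibition of aldehyde dehydrogenase 1A1 (Homo sapiens), read by spectrophotometry, tested at 10 uM (on this read-out higher numbers stand for more inhibition at the one concentration tested (going by the name of the read-out) and lower numbers for less inhibition), compound 1 gives the lowest of the three numbers; compound 2 lies within the scatter of it, while compound 3 lies well beyond it. Within the data shown here, the only single-place step measured, a number 46.9 percentage points higher from compound 2 to compound 3 (beyond the scatter), concerns the group on the carbonyl carbon, which compound 4 `O=C(C1CC1)N1CCN(Cc2nc3ccccc3n2Cc2ccccc2F)CC1` keeps unchanged from compound 1. Among the measured compounds shown here, the change 2-fluorophenyl in place of methyl on a saturated chain carbon bound to an aromatic nitrogen sits elsewhere, and no measured step touches that place; compound 1 and compound 2 differ in more than one place, and their values are within the scatter of each other. The step of a number 7.2 percentage points higher from compound 1 to compound 4 (within the scatter) is therefore expected to be small, with no direction beyond the scatter assumed. Compound 4 is estimated at 28%, within 10% to 50%.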

Compound 4, a percentage reported as inhibition, at one concentration (the size of the read-out at that concentration, not a potency): 40.7%
Estimate against measurement, compound 4: 12.7 percentage points below; the measured number falls inside the stated range.
By their numbers in this assay, from the lowest: compounds 1 and 2 (each within the scatter of the next); then compound 4; then compound 3.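

In this assay the change from ethyl to 2-fluorobenzyl gives a number 19.9 percentage points higher from compound 1 to compound 4 (beyond the scatter), the first step read at this place, on a saturated chain carbon bound to an aromatic nitrogen. The read-out therefore responds to this position as well as to the group on the carbonyl carbon, and it does so with the cyclopropyl amide of compound 1 kept unchanged. No measurement at hand offers a reason for this step. As far as these compounds go, how much of it belongs to the aromatic ring and how much to the fluorine stays open. An unsubstituted benzyl or a propyl chain at this place would bear on that question.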